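The source may hold more compounds than are shown below. What is called first, only, known or untested is meant among the compounds shown, and "the series" means these compounds.

Among the three compounds measured in a functional assay on T47D cells (Homo sapiens) for inhibition, read by sulforhodamine B assay, with a stated time of 48 h, tested at 10 uM (on this read-out higher numbers stand for more inhibition at the one concentration tested (going by the name of the read-out) and lower numbers for less inhibition), compound 3 `Brc1ccc(-c2cn3ccnc3c(-c3ccc4ncn(C5CCCCC5)c4c3)n2)cc1` gives 55%, the largest of the three values, although compound 1 `Brc1cn2ccnc2c(-c2ccc3ncn(C4CCCCC4)c3c2)n1` with 49.7% lies within the scatter of it, while compound 2 `Clc1ccc(-c2cn3ccnc3c(-c3ccc4ncn(C5CCCCC5)c4c3)n2)cc1` with 27.6% lies beyond it. The step to compound 4 `Fc1ccccc1-c1cn2ccnc2c(-c2ccc3ncn(C4CCCCC4)c3c2)n1` is 2-fluorophenyl in place of 4-bromophenyl on an aromatic carbon. For the measured compounds named here, two measured steps bear on it: a number 27.4 percentage points higher from compound 2 to compound 3 (beyond the scatter) shows that the halogen on the phenyl matters, and a number 5.3 percentage points higher from compound 1 to compound 3 (within the scatter) shows that adding the 4-bromophenyl changed little. From the compounds shown here alone, since fluorine is not among the halogens tried and the 2-fluorophenyl is untested, a decrease of modest size is expected in this assay. Compound 4 is therefore expected to give about 32%, between 12% and 55%. This expectation means a step of a number 23 percentage points lower from compound 3 to compound 4 (beyond the scatter).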

Compound 4, a percentage reported as inhibition, at one concentration (the size of the read-out at that concentration, not a potency): 77.2%
The estimate for compound 4 lay 45.2 percentage points below the measured number; the measured number lies above the stated range.
By their numbers in this assay, from the lowest: compound 2; then compounds 1 and 3 (each within the scatter of the next); then compound 4.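

In this assay, for the compounds shown here, a phenyl on this aromatic carbon can do more than the earlier compounds showed: the 2-fluorophenyl gives a number 22.2 percentage points higher from compound 3 to compound 4 (beyond the scatter), a number 27.5 percentage points higher from compound 1 to compound 4 (beyond the scatter) and a number 49.6 percentage points higher from compound 2 to compound 4 (beyond the scatter), so compound 4 stands highest of the four. Going by these compounds alone, compound 4 is thus the only aryl compound here whose number clears that of the bromo compound 1, beyond the scatter. No measurement shown here accounts for this rise. From the compounds shown here alone, the halogen and its ring position change together in this step, so their shares remain open. A 4-fluorophenyl or a 2-chlorophenyl would separate them.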